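A few compounds are considered here, and "the series" means these few. Any claim that something is new, unique, unknown or untested is made for them only; others in the source may bear on it.

In a functional assay on DU-145 cells (Homo sapiens) for inhibition, read by trypan blue exclusion, with a stated time of 72 h (on this read-out lower numbers stand for stronger inhibition and higher numbers for weaker inhibition), compound 2 `Cn1c(=O)c(S(=O)(=O)c2ccc(F)cc2F)cc2cnc(Nc3ccc4occc4c3)nc21` gives 15000 nM. Compound 3 `Cc1ccc(S(=O)(=O)c2cc3cnc(Nc4ccc5cc[nH]c5c4)nc3n(C)c2=O)cc1` gives 15000 nM, and these two numbers stand level at the digits shown, together the highest of the three measured. Compound 1 `Cn1c(=O)c(S(=O)(=O)c2ccc(F)cc2)cc2cnc(Nc3ccc4occc4c3)nc21` gives 5000 nM; the exchange of fluoro in place of hydrogen on an aromatic carbon brought a 3.0-fold higher number from compound 1 to compound 2 (0.48 log units; beyond the scatter), a modest shift toward weaker inhibition.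

Compound 4 `Cc1cc2cc(Nc3ncc4cc(S(=O)(=O)c5ccc(F)cc5F)c(=O)n(C)c4n3)ccc2[nH]1` differs from compound 2 in one place: 2-methyl-1H-indol-5-yl in place of 1-benzofuran-5-yl on a nitrogen on an aromatic ring

Among the measured compounds shown here, no measured step captures this exchange by itself. For the measured compounds named here, compound 3 carries an indol-5-yl group and compound 1 a 1-benzofuran-5-yl group, but the two also differ in the sulfonyl part, so their pair cannot be read as one step; their values show only that compound 1 sits at the lower number. With nothing pointing clearly either way, the step from compound 2 to compound 4 is expected to stay within the scatter, a 1.5-fold lower number from compound 2 to compound 4 (0.18 log units; within the scatter). Compound 4 is therefore estimated at 10000 nM, in a range from 3000 nM to 40000 nM.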

Compound 4, half-maximal inhibitory concentration: 750 nM
Compound 4: middle estimate off by 13-fold (1.12 log units), on the high side; measured number outside the range, below it.
By their numbers in this assay, from the lowest: compound 4; then compound 1; then compounds 2 and 3 (each within the scatter of the next).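

In this assay the group on the nitrogen turns out to matter far more than the earlier fluoro exchange suggested: 2-methyl-1H-indol-5-yl in place of 1-benzofuran-5-yl gives a 20-fold lower number from compound 2 to compound 4 (1.30 log units; beyond the scatter) with the rest of the molecule unchanged. The earlier compounds shown here could not show this, since compound 3 differs from compounds 1 and 2 in the sulfonyl part as well. The exchange alters both the hetero atom of the five-membered ring and the methyl together, so this single step cannot divide the shift between them, and nothing available explains its size.

Going by these compounds, whether the shift comes from the ring nitrogen or from the methyl stays open. So does whether an ethyl group or a carboxylic acid in place of that methyl would keep the lower number.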